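Replacing the Cyanophenyl of Compound 1: Cytotoxicity Outlook for Compound 4

The compounds below may be only part of what the source reports. "The series", "measured", "known", "first", "only" and "open" are said of these compounds alone.

compound 1 `N#Cc1cccc(C(=O)NC(=S)N2CCc3c(OCCCCCOc4ccc(Cl)cc4)cccc32)c1` — 9750 nM
compound 2 `N#Cc1ccc(C(=O)NC(=S)N2CCc3c(OCCCCCOc4ccc(Cl)cc4)cccc32)cc1` — > 50000 nM
compound 3 `CN(C)c1ccc(C(=O)NC(=S)N2CCc3c(OCCCCCOc4ccc(Cl)cc4)cccc32)cc1` — > 50000 nM

Among the compounds with values here, in an ADME assay on Huh-7 cells (Homo sapiens) for cytotoxicity (a lower number here means that less compound is tolerated, a higher number that more compound is tolerated), compound 1 gives 9750 nM, the only plain number among the three compounds. Compound 2 gives > 50000 nM, which is a limit of the assay. Compound 3 gives > 50000 nM, likewise a limit. Two of the three results therefore sit at the limit of > 50000 nM in this assay, at which 2 of the 3 values shown sit. Both changes away from the shared core of compound 1 raise the number: an at least 5.1-fold higher number from compound 1 to compound 2 (0.70 log units; beyond the scatter), and an at least 5.1-fold higher number from compound 1 to compound 3 (0.70 log units; beyond the scatter). Between the two limits nothing can be read: a step that the two limits leave unreadable from compound 2 to compound 3.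

Compound 4 `O=C(NC(=S)N1CCc2c(OCCCCCOc3ccc(Cl)cc3)cccc21)c1cccnc1` has not yet been measured. It differs from compound 1 in one place: pyridin-3-yl in place of 3-cyanophenyl on a carbonyl carbon. Both measured steps that leave the 3-cyanophenyl of compound 1 are at least modest rises, so an increase is expected for compound 4 as well, though whether it reaches the limit cannot be told from two limits. The step is expected to be a 3.1-fold higher number from compound 1 to compound 4 (0.49 log units; beyond the scatter). Compound 4 is estimated at 30000 nM, with a range from 10000 nM to 80000 nM.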

Compound 4, half-maximal cytotoxic concentration: 11100 nM
Estimate against measurement, compound 4: 2.7-fold (0.43 log units) above, and the stated range covers the measured number.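

In this assay, within the data shown here, the earlier compounds suggested that any move away from 3-cyanophenyl on this carbonyl carbon would raise the number, but pyridin-3-yl does not do so (a 1.1-fold higher number from compound 1 to compound 4 (0.06 log units; within the scatter)). Leaving 3-cyanophenyl is therefore not enough by itself, and the change from 3-cyanophenyl to pyridin-3-yl, which removes the nitrile and puts a nitrogen into the ring, leaves the result within the scatter. The 4-cyanophenyl and 4-(dimethylamino)phenyl groups both stand apart from pyridin-3-yl (an at least 4.5-fold lower number from compound 2 to compound 4 (0.65 log units; beyond the scatter)) (an at least 4.5-fold lower number from compound 3 to compound 4 (0.65 log units; beyond the scatter)), yet these steps give only a minimum size and the step between compound 2 and compound 3 cannot be read, because both values are limits: the limit of > 50000 nM in this assay, at which 2 of the 4 values shown sit.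

The compounds shown leave open whether pyridin-4-yl or 3-(dimethylamino)phenyl on this carbonyl carbon would stay close to compound 1 and compound 4 or would reach the limit shared by compound 2 and compound 3. They also leave open where plain phenyl would fall, and how far above the limit compound 2 and compound 3 really lie.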